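Bromofuran to chlorophenyl on an acrylamide-type series

This account rests on a few compounds, and the source may have more. Where it says the series, first, only, none or still open, it means among the compounds named here.

Measured compounds in a functional assay on NCI-H460 cells (Homo sapiens) for inhibition, read by MTT assay, with a stated time of 72 h; a higher number here means a weaker inhibitor of growth, a lower number a stronger inhibitor of growth:
Compound 1, `COc1ccc(CNC(=O)/C(C#N)=C/c2ccco2)cc1`: compound 1 gives 32000 nM.
Compound 2, `COc1ccc(CNC(=O)/C(C#N)=C/c2ccc(C)o2)cc1`: compound 2 reaches only the limit > 100000 nM.
Compound 3, `COc1ccc(CNC(=O)/C(C#N)=C/c2cc(Br)co2)cc1`: compound 3 reaches only the limit > 100000 nM.

Compound 3 thus stands at a limit of this assay rather than at a number, and it shares that position with compound 2, as the limit of > 100000 nM in this assay, at which 2 of the 3 values shown sit, records. Among the measured compounds shown here, the one readable step to it is an at least 3.1-fold higher number from compound 1 to compound 3 (0.49 log units; beyond the scatter), with the change being bromo in place of hydrogen on an aromatic carbon; the parallel step an at least 3.1-fold higher number from compound 1 to compound 2 (0.49 log units; beyond the scatter) concerns methyl in place of hydrogen on an aromatic carbon. The step between compound 2 and compound 3 is a step that the two limits leave unreadable from compound 2 to compound 3.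

Compound 4, `COc1ccc(CNC(=O)/C(C#N)=C/c2ccc(Cl)cc2)cc1`, has not been measured. The change is 4-chlorophenyl in place of 4-bromofuran-2-yl on a double-bonded chain carbon bound to a double-bonded chain carbon. For the measured compounds named here, no measured step replaces one aromatic ring by another, so the estimate rests on compound 1 at 32000 nM as the only numerical anchor. Compound 2 and compound 3 add no number to it, only the positions at the limit already described. Compound 4 is expected to give about 40000 nM, within a broad range from 8000 nM to 200000 nM, an expected step of an at least 2.5-fold lower number from compound 3 to compound 4 (0.39 log units; beyond the scatter) that may again end at a limit.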

Compound 4, concentration for 50% growth inhibition: 14000 nM
Estimate against measurement, compound 4: 2.9-fold (0.46 log units) above; measured number inside the range.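

Among the compounds shown here, at the double-bonded chain carbon bound to a double-bonded chain carbon, the earlier compounds showed only substituted furans moving to a limit, whereas a substituted six-membered ring of carbon only reads as a number in this assay, with an at least 7.1-fold lower number from compound 3 to compound 4 (0.85 log units; beyond the scatter) and an at least 7.1-fold lower number from compound 2 to compound 4 (0.85 log units; beyond the scatter). Both steps are open-ended, since compound 2 and compound 3 stand at a limit and not at a number: the limit of > 100000 nM in this assay, at which 2 of the 4 values shown sit. The 4-chlorophenyl group also outdoes the unsubstituted furan, with a 2.3-fold lower number from compound 1 to compound 4 (0.36 log units; beyond the scatter), which makes compound 4 the strongest inhibitor of growth of the four.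

Whether this step belongs to the six-membered ring or to the chlorine stays open, as no plain phenyl stands among these compounds. From the compounds shown here alone, how an amine or a carboxylic acid on that ring would read also remains unknown.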